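From cyclopentyl to 3-hydroxypropyl on a shared core

The source may report more compounds than this note shows. Statements on the series, on what has been measured and on what is new or still open speak of the compounds shown alone.

- Compound 1 `COc1ccc(Nc2nc(NCCCO)c3ccccc3n2)cc1`: 15200 nM
- Compound 2 `COc1ccc(N(C)c2nc(NC3CCCC3)c3ccccc3n2)cc1`: 9400 nM
- Compound 3 `COc1ccc(N(C)c2nc(NCCCO)c3ccccc3n2)cc1`: not yet measured

In a functional assay on A549 cells (Homo sapiens) for antiproliferative activity, read by sulforhodamine B assay, with a stated time of 48 h (on this read-out lower numbers stand for stronger inhibition of growth and higher numbers for weaker inhibition of growth), compound 2 at 9400 nM stands within the usual scatter of compound 1 at 15200 nM. Compound 3 differs from compound 2 in one group: 3-hydroxypropyl in place of cyclopentyl on a nitrogen on an aromatic ring. Among the compounds with values here, no measured pair shows this change alone. Compound 1, which also bears 3-hydroxypropyl, gives 15200 nM, so no shift beyond the scatter is expected in this assay. The expected step of a 1.2-fold higher number from compound 2 to compound 3 (0.07 log units; within the scatter) therefore has no firm direction. For compound 3 the estimated value is 11000 nM, with an expected range from 3500 nM to 35000 nM.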

Compound 3, concentration for 50% growth inhibition: 13000 nM
Compound 3: the middle estimate sits 1.2-fold (0.07 log units) below what was measured; the measured number falls inside the stated range.
By their numbers in this assay, from the lowest: compounds 2, 3 and 1 (each within the scatter of the next).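

In this assay, 3-hydroxypropyl in place of cyclopentyl on a nitrogen on an aromatic ring, now seen alone, gives a 1.4-fold higher number from compound 2 to compound 3 (0.14 log units; within the scatter), so this exchange of a ring for an open chain leaves the number within the scatter. Methyl in place of hydrogen on a nitrogen on an aromatic ring, also seen alone, gives a 1.2-fold lower number from compound 1 to compound 3 (0.07 log units; within the scatter), again within the scatter. Nothing measured here bears on why these steps stay so small.

From the compounds shown here alone, whether an amine, a carboxylic acid or a longer chain in place of 3-hydroxypropyl would give a step beyond the scatter stays open. So does whether ethyl in place of methyl would.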